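Cyclohexyl Gives Way to 4-Chlorobenzyl on the Amine Nitrogen

This account rests on a few compounds, and the source may have more. Where it says the series, first, only, none or still open, it means among the compounds named here.

Within the data shown here, compound 3 `Cc1cc(CNC2CCCCC2)c(C)n1-c1ccc(Cl)cc1` gives 10 ug/mL in an ADME assay on RAW264.7 cells (Mus musculus) for cytotoxicity, read by trypan blue exclusion, with a stated time of 48 h (a higher number here means a weaker inhibitor of growth, a lower number a stronger inhibitor of growth), the second highest of the three numbers so far. Compound 1 `Cc1cc(CNCc2ccc(F)cc2)c(C)n1-c1ccc(Cl)cc1` gives 26 ug/mL, and compound 2 `Cc1ccc(CNCc2cc(C)n(-c3ccc(Cl)cc3)c2C)cc1` gives 0.1 ug/mL. The step of a 2.6-fold lower number from compound 1 to compound 3 (0.41 log units; beyond the scatter) is modest, whereas a 100-fold higher number from compound 2 to compound 3 (2.00 log units; beyond the scatter) is large; the two benzyl groups themselves stand far apart, since a 260-fold lower number from compound 1 to compound 2 (2.41 log units; beyond the scatter).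

Compound 4 `Cc1cc(CNCc2ccc(Cl)cc2)c(C)n1-c1ccc(Cl)cc1` differs from compound 3 in one place: 4-chlorobenzyl in place of cyclohexyl on an amine nitrogen. The two steps that bear on this change are the ones that put cyclohexyl in place of a benzyl, and read backwards they point in opposite directions, one modest and upward, one large and downward. A 4-chlorobenzyl group is a benzyl with one substituent on its ring, like those of compound 1 and compound 2, so he expects compound 4 to fall between those two outcomes, most likely lower than compound 3, with a wide band of uncertainty. His estimate for compound 4 in this assay is 3 ug/mL, ranging from 0.3 ug/mL to 30 ug/mL. This expected value corresponds to a 3.3-fold lower number from compound 3 to compound 4 (0.52 log units; beyond the scatter).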

Compound 4, concentration for 50% growth inhibition: 0.1 ug/mL
The estimate for compound 4 lay 30-fold (1.48 log units) above the measured number; measured number outside the range, below it.
By their numbers in this assay, from the lowest: compounds 2 and 4 (each within the scatter of the next); then compound 3; then compound 1.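

In this assay, the step of a 100-fold lower number from compound 3 to compound 4 (2.00 log units; beyond the scatter) shows that 4-chlorobenzyl on the amine nitrogen lies far from the modest outcome seen with compound 1. Chloro in place of methyl on the benzyl ring gives no change at the digits printed from compound 2 to compound 4 (within the scatter) and so leaves compound 2 and compound 4 together, while chloro in place of fluoro gives a 260-fold lower number from compound 1 to compound 4 (2.41 log units; beyond the scatter) and so leaves compound 1 alone among these three benzyl compounds, with the whole gap resting on that one ring substituent. Nothing shown here explains why the fluoro compound stands so far from the chloro and methyl compounds.

From the compounds shown here alone, it remains open whether an unsubstituted benzyl, or a bromo or methoxy group on that ring, would track compound 1 or compound 4. Also open, going by these compounds, is how a longer chain or a carboxylic acid on the amine nitrogen would compare with 4-chlorobenzyl.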